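A few compounds are considered here, and "the series" means these few. Any claim that something is new, unique, unknown or untested is made for them only; others in the source may bear on it.

Series values in a functional assay on SMMC-7721 cells (Homo sapiens) for antiproliferative activity, read by MTT assay, with a stated time of 48 h; a lower number here means a stronger inhibitor, a higher number a weaker inhibitor:
- Compound 1 `CC(C)=CCC[C@]1(C)/C=C/[C@@H](OC(=O)C=C(C)C)[C@](C)(O)/C=C/C(=O)/C(CN(C(C)C)C(C)C)=C\C1`: 340 nM
- Compound 2 `CC(C)=CCC[C@]1(C)/C=C/[C@@H](OC(=O)C=C(C)C)[C@](C)(O)/C=C/[C@H](O)/C(CO)=C\C1`: > 40000 nM (a limit of the assay, not a number)
- Compound 3 `CC(=O)O[C@@H]1/C=C/[C@@](C)(CCC=C(C)C)C/C=C(/CO)C(=O)/C=C/[C@@]1(C)O`: 9870 nM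

Of the two numerical values, compound 3 at 9870 nM holds the higher, so it is the weaker inhibitor of that pair. Compound 1 lies lower at 340 nM, a gap beyond the usual scatter.

The next compound, compound 4 `CC(C)=CCC[C@]1(C)/C=C/[C@@H](OC(=O)C(C)C)[C@](C)(O)/C=C/C(=O)/C(CO)=C\C1`, differs from compound 3 in a single place: isopropyl in place of methyl on a carbonyl carbon. In words, isopropyl stands in place of methyl on a carbonyl carbon, which turns acetoxy into (isopropylcarbonyl)oxy.

Within the data shown here, no measured pair isolates this change, so the expectation is anchored on compound 3 at 9870 nM. A small move towards a lower number in this assay is expected, most likely not beyond the scatter, and a larger move in either direction cannot be ruled out. The estimated change is a 1.4-fold lower number from compound 3 to compound 4 (0.15 log units; within the scatter). For compound 4 the estimated value is 7000 nM, with an expected range of 2500 nM to 20000 nM.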

Compound 4, half-maximal inhibitory concentration: 10400 nM
Compound 4: middle estimate off by 1.5-fold (0.17 log units), on the low side; the range from low to high includes it.
By their numbers in this assay, from the lowest: compound 1; then compounds 3 and 4 (each within the scatter of the next). At a limit, above all of these: compound 2.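

In this assay, among these compounds, this is the first single-place comparison, and it gives a 1.1-fold higher number from compound 3 to compound 4 (0.02 log units; within the scatter) for isopropyl in place of methyl on a carbonyl carbon, turning acetoxy into (isopropylcarbonyl)oxy. At this position, then, the change from 1 heavy atom leaving to 3 heavy atoms entering, with no ring and no hydrogen-bond donor or acceptor on either side, leaves compound 3 and compound 4 indistinguishable in this read-out, so the acyl group can go from acetyl to isopropylcarbonyl without a readable shift. Nothing in the data at hand bears on why this step stays within the scatter.

Going by these compounds, two small alkyl groups on one carbonyl carbon say little about the wider range of this position, so it remains open whether a longer chain such as pentyl, a phenyl ring, or an amine on that carbonyl carbon, which would make a carbamate, would also leave the value in place. On these data alone, it is also open whether the same step would hold on a core carrying a different group elsewhere, or in any read-out other than this assay.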